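Swapping a propyl chain for a pyrrolidine ring

The source may report more compounds than this note shows. Statements on the series, on what has been measured and on what is new or still open speak of the compounds shown alone.

Measured compounds:
Compound 1, `COc1ncc(-c2nc(C(F)(F)F)sc2N2CCN(C(=O)Cn3nc(C)nc3C)[C@H](C)C2)cn1`: 558 nM
Compound 2, `CCCc1ncc(-c2nc(C(F)(F)F)sc2N2CCN(C(=O)Cn3nc(C)nc3C)[C@H](C)C2)cn1`: 258 nM

Two compounds share one core and differ only in the group attached to an aromatic carbon. In a functional assay on U2OS cells for antagonist activity at C-X-C chemokine receptor type 3 (Homo sapiens), read by beta-arrestin recruitment (a higher number here means a weaker inhibitor, a lower number a stronger inhibitor), compound 1 gives 558 nM, and compound 2 gives 258 nM. Among the measured compounds shown here, the single measured step, a 2.2-fold lower number from compound 1 to compound 2 (0.34 log units; beyond the scatter), is modest but lies beyond the usual scatter. Compound 2 therefore holds the lower of the two numbers and is the stronger inhibitor of the pair.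

Compound 3, `Cc1nc(C)n(CC(=O)N2CCN(c3sc(C(F)(F)F)nc3-c3cnc(N4CCCC4)nc3)C[C@H]2C)n1`, has not yet been measured. It differs from compound 2 in one place: pyrrolidin-1-yl in place of propyl on an aromatic carbon. For the measured compounds named here, only one measured step bears on this position, a 2.2-fold lower number from compound 1 to compound 2 (0.34 log units; beyond the scatter), and it shows that exchanging the group there moved the number modestly. Going by the values given here, no measured compound carries a ring at this position, so the data do not fix the direction for a pyrrolidin-1-yl group; a modest step either way, or none beyond the scatter, is plausible. Compound 3 is expected to give about 220 nM, within 60 nM to 800 nM. The expected step is a 1.2-fold lower number from compound 2 to compound 3 (0.07 log units; within the scatter).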

Compound 3, half-maximal inhibitory concentration: 523 nM
Compound 3: the middle estimate sits 2.4-fold (0.38 log units) below what was measured, within the range that was stated.
By their numbers in this assay, from the lowest: compound 2; then compounds 3 and 1 (each within the scatter of the next).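

The pyrrolidin-1-yl ring cancels the gain seen with the propyl chain in this assay (a 2.0-fold higher number from compound 2 to compound 3 (0.31 log units; beyond the scatter)), and it cannot be told apart from the methoxy group of compound 1 (a 1.1-fold lower number from compound 1 to compound 3 (0.03 log units; within the scatter)). This position therefore does not reward every group that replaces methoxy, and a larger group containing a ring, with a nitrogen atom attached to the aromatic carbon, gives no advantage here. Among the compounds shown here, compound 2 is now the strongest inhibitor of the three, and propyl is the only one of the three groups that joins the aromatic carbon through a carbon atom, although three compounds are too few to call this a rule, and nothing available explains why propyl stands apart.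

The compounds shown leave open whether a ring joined through carbon, such as cyclopentyl, would match compound 2 or compound 3, which would help separate the effect of the ring from that of the attaching atom. They also leave open whether a longer chain such as butyl would improve on propyl, and whether an open-chain amine such as dimethylamino would behave like the pyrrolidin-1-yl ring.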